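Methoxy in Place of Chloro in an Unresponsive Urea Series

A few compounds are considered here, and "the series" means these few. Any claim that something is new, unique, unknown or untested is made for them only; others in the source may bear on it.

In a functional assay on MDA-MB-231 cells (Homo sapiens) for antiproliferative activity, read by MTT assay, with a stated time of 72 h (on this read-out higher numbers stand for weaker inhibition and lower numbers for stronger inhibition), compound 1 `O=C(Nc1ccc(S(=O)(=O)Nc2cccc(-c3nc(-c4ccc(NC(=O)c5cccnc5)cc4Cl)no3)c2)cc1)NC1CCCC1` gives only a limit, > 10000 nM. Compound 2 `O=C(Nc1ccccc1)Nc1cccc(-c2nc(-c3ccc(NC(=O)c4cccnc4)cc3Cl)no2)c1` likewise gives only a limit in this assay, > 10000 nM. Compound 3 `O=C(Nc1ccc(Cl)cc1)Nc1cccc(-c2nc(-c3ccc(NC(=O)c4cccnc4)cc3Cl)no2)c1` as well gives only a limit in this assay, > 10000 nM. The step that the two limits leave unreadable from compound 2 to compound 3, chloro in place of hydrogen on an aromatic carbon, cannot be read because all three values sit at the limit of > 10000 nM in this assay, at which 3 of the 3 values shown sit. Compound 4 `COc1ccc(NC(=O)Nc2cccc(-c3nc(-c4ccc(NC(=O)c5cccnc5)cc4Cl)no3)c2)cc1` differs from compound 3 by methoxy in place of chloro on an aromatic carbon. Going by the values given here, no measured step gives a direction here, so the step that the limit leaves unreadable from compound 3 to compound 4 is expected to be none beyond the scatter. Compound 4 is therefore expected at 20000 nM, between 8000 nM and 60000 nM, most likely again reported as a limit.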

Compound 4, half-maximal inhibitory concentration: 3000 nM
Beside the measured number, compound 4's estimate is 6.7-fold (0.82 log units) above it; measured number outside the range, below it.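

In this assay, going by these compounds alone, the 4-methoxyphenyl group gives the first readable change at this position: methoxy in place of chloro gives an at least 3.3-fold lower number from compound 3 to compound 4 (0.52 log units; beyond the scatter) and methoxy in place of hydrogen gives an at least 3.3-fold lower number from compound 2 to compound 4 (0.52 log units; beyond the scatter) in the same comparison. The step from hydrogen to chloro cannot be read, so this position responds to at least one group but shows no direction before methoxy. Compound 4 alone carries a number rather than a limit: the limit of > 10000 nM in this assay, at which 3 of the 4 values shown sit. Going by these compounds, whether an ethoxy group, a hydroxy group or an amine here would also lower the number stays open. On these data alone, the true size of both steps also stays open, since each rests on a limit.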